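The source may hold more compounds than are shown below. What is called first, only, known or untested is meant among the compounds shown, and "the series" means these compounds.

Compound 1 `COc1ccc(C(=O)/C=C/c2ccc(F)cc2)c2c1C=CC(C)(C)O2`. In a functional assay on HCT-116 cells (Homo sapiens) for antiproliferative activity, read by MTT assay, with a stated time of 24 h (on this read-out higher numbers stand for weaker inhibition and lower numbers for stronger inhibition), compound 1 gives only a limit, > 10000 nM.
Compound 2 `COc1ccc(C(=O)/C=C/c2ccc(N(C)C)cc2)c2c1C=CC(C)(C)O2`. In this assay compound 2 gives 1920 nM.

Within the data shown here, compound 2 stands as the only numerical value; the other value is a limit of this assay. Among the measured compounds shown here, the one measured step, an at least 5.2-fold lower number from compound 1 to compound 2 (0.71 log units; beyond the scatter), is bounded by the limit, (the limit of > 10000 nM in this assay, at which 1 of the 2 values shown sits), so its true size is only a lower bound.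

Compound 3 `COc1ccc(C(=O)/C=C/c2ccc(-c3ccccc3)cc2)c2c1C=CC(C)(C)O2` differs from compound 2 by phenyl in place of dimethylamino on an aromatic carbon. The measured step bears on this change only indirectly: it shows that dimethylamino, which now leaves, was the group that brought the series to a measurable number, while fluoro at the same carbon gave a limit. Whether phenyl behaves like fluoro or like dimethylamino is not shown by any measured pair, so the direction of the step in this assay is open, with some chance that compound 3 again yields a limit. Compound 3 is expected at 3500 nM, within 900 nM to 15000 nM. The estimated step is a 1.8-fold higher number from compound 2 to compound 3 (0.26 log units; within the scatter).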

Compound 3, half-maximal inhibitory concentration: > 10000 nM
Compound 3: no number, only a limit; the forecaster's own chance of this, stated with the estimate: 30%; middle value at least 2.8-fold (0.45 log units) away from the limit.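

Replacing dimethylamino with phenyl on this aromatic carbon, para to a large group, gives an at least 5.2-fold higher number from compound 2 to compound 3 (0.71 log units; beyond the scatter), so the measurable number of compound 2 does not survive this change in this assay. Among these compounds, until now, dimethylamino had been compared only with fluoro, and a second replacement, larger and carrying a six-membered aromatic ring of carbon only, also ends at a limit, so compound 2 remains the only one of the three compounds with a number at this position. Two different groups thus give the same kind of result, and most of the series now rests at the edge of what the assay reports: the limit of > 10000 nM in this assay, at which 2 of the 3 values shown sit.

On these data alone, the step between compound 1 and compound 3 cannot be read, since both are limits, and how far either compound lies beyond its limit remains unknown, so fluoro and phenyl cannot be ranked against each other. As far as these compounds go, it also remains open whether the number depends on dimethylamino itself or would persist with another amine at this carbon, such as pyrrolidine, morpholine or a primary amine, or with a methoxy group.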